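This account rests on a few compounds, and the source may have more. Where it says the series, first, only, none or still open, it means among the compounds named here.

In a functional assay on the whole organism (strain albino) with Mus musculus as the target, with a stated time of 0.5 h (on this read-out lower numbers stand for an effect already at smaller amounts and higher numbers for an effect only at larger amounts of compound), compound 1 `COc1ccc(C2CC(Nc3nc4ccc(C)cc4s3)=NN2C(C)=O)cc1O` gives 75.6 umol/kg as its dose for half-maximal effect. Compound 2 `COc1ccc(C2CC(Nc3nc4ccc([N+](=O)[O-])cc4s3)=NN2C(C)=O)cc1O` offers no such figure: its entry in this assay reads "not determined" (no result reported) and no result is reported, so it cannot be placed relative to compound 1. Compound 3 `CC(=O)N1N=C(Nc2nc3ccc([N+](=O)[O-])cc3s2)CC1c1ccc(Cl)cc1` differs from compound 2 in a single place, with 4-chlorophenyl in place of 3-hydroxy-4-methoxyphenyl on a saturated ring carbon. Among the compounds with values here, no step between measured compounds exists, so the data give no measured size for a change of this kind. In this assay no shift beyond the usual scatter, in either direction, is expected, with compound 1 at 75.6 umol/kg as the only anchor. Expected for compound 3 is 70 umol/kg as the middle value, with 25 umol/kg to 200 umol/kg as its estimated range.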

Compound 3, dose for half-maximal effect: 138 umol/kg
Estimate against measurement, compound 3: 2.0-fold (0.29 log units) below; low and high end bracket the measured number.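

No new step can be read from this result: compound 3 differs in one place from compound 2, whose entry in this assay gives no number. The compounds shown leave open how 4-chlorophenyl in place of 3-hydroxy-4-methoxyphenyl shifts the dose, and no supporting data bear on this result.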